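Working notes: from compound 3 to compound 4

The compounds below may be only part of what the source reports. "The series", "measured", "known", "first", "only" and "open" are said of these compounds alone.

Three compounds of the series have been run in a functional assay on MDA-MB-231 cells (Homo sapiens) for antiproliferative activity, read by MTT assay, with a stated time of 72 h; on this read-out lower numbers stand for stronger inhibition of growth and higher numbers for weaker inhibition of growth. Compound 1 `c1ccc(/N=c2\ssnc2-c2ccccc2)cc1` carries phenyl on the shared core; in this assay compound 1 gives > 10000 nM, which is a limit of the assay rather than a number. Compound 2 `c1ccc(/N=c2\ssnc2-c2ccco2)cc1` carries furan-2-yl in place of phenyl and gives > 10000 nM, again only a limit. Compound 3 `c1ccc(/N=c2\ssnc2-c2cccs2)cc1` carries thiophen-2-yl and also stands at a limit, > 10000 nM. The steps between these three, a step that the two limits leave unreadable from compound 1 to compound 2, a step that the two limits leave unreadable from compound 1 to compound 3 and a step that the two limits leave unreadable from compound 2 to compound 3, cannot be sized, since (the limit of > 10000 nM in this assay, at which 3 of the 3 values shown sit). Compound 4 `Cc1nss/c1=N\c1ccccc1` is the next analogue: methyl in place of thiophen-2-yl on an aromatic carbon. Among the compounds with values here, no measured step replaces the aromatic group with an alkyl group, so the three unreadable steps bear on it only by showing that varying that group has so far brought no compound under the limit. The step from compound 3 to compound 4 is therefore expected to be a step that the limit leaves unreadable from compound 3 to compound 4, most likely leaving compound 4 at the limit again. Compound 4 is estimated at 15000 nM in this assay, with a range of 5000 nM to 50000 nM.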

Compound 4, concentration for 50% growth inhibition: > 10000 nM
Compound 4: only a limit was reported; the forecaster's own chance of this, stated with the estimate: 85%; the middle value does not contradict the limit.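

Within the data shown here, no step to compound 4 from compound 1, compound 2 or compound 3 can be read, since each value is only a limit: the limit of > 10000 nM in this assay, at which 4 of the 4 values shown sit. The compounds shown leave open whether any group at this place brings a compound under that limit.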